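Replacing phenoxy with pentyl on the chain of compound 2

The compounds below may be only part of what the source reports. "The series", "measured", "known", "first", "only" and "open" are said of these compounds alone.

Among the measured compounds shown here, compound 2 `CN1CCN(c2nc3ccccc3n2CCOc2ccccc2)CC1` is the one whose number in a functional assay on ileum for inhibition of histamine H1 receptor (Cavia porcellus) (a lower number here means a stronger inhibitor, a higher number a weaker inhibitor), is lowest of the three so far, with compound 2 giving 6.9 nM; compound 1 `CCCN1CCCN(c2nc3ccccc3n2CCOCC)CC1` gives 8.4 nM and compound 3 `CCCCN1CCCN(c2nc3ccccc3n2CCOCC)CC1` gives 8.4 nM, and both of these lie within the scatter of compound 2, so no order among the three can be claimed. For the measured compounds named here, the one measured step, no change at the digits printed from compound 1 to compound 3 (within the scatter), shows that lengthening the chain on the amine nitrogen side of the core leaves the assay untouched.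

Compound 4 `CCCCCCCn1c(N2CCN(C)CC2)nc2ccccc21` differs from compound 2 by pentyl in place of phenoxy on a saturated chain carbon, two bonds along the chain from an aromatic nitrogen. Going by the values given here, no measured pair changes this part of the molecule, so the step from compound 1 to compound 3 bears on it only loosely, as another case where carbons are added to a chain without any shift in this assay. Compound 1 and compound 2, which differ in two places, show values within the scatter of each other, which again suggests that the group at this end of the chain is not decisive here. Compound 4 is therefore expected to stay close to compound 2, with the estimated step being a 1.7-fold higher number from compound 2 to compound 4 (0.24 log units; within the scatter). The estimate for compound 4 in this assay is 12 nM, within a range from 4 nM to 40 nM.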

Compound 4, half-maximal inhibitory concentration: 150 nM
Beside the measured number, compound 4's estimate is 13-fold (1.10 log units) below it; measured number above the stated range.
By their numbers in this assay, from the lowest: compounds 2, 1 and 3 (each within the scatter of the next); then compound 4.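

In this assay, putting pentyl in place of phenoxy on a saturated chain carbon, two bonds along the chain from an aromatic nitrogen, gives a 22-fold higher number from compound 2 to compound 4 (1.34 log units; beyond the scatter), so the group held at this position clearly matters for this read-out. Among the compounds shown here, the only earlier step, no change at the digits printed from compound 1 to compound 3 (within the scatter), added a methyl on a saturated chain carbon, three bonds along the chain from an amine nitrogen in a ring, and its lack of effect at that place does not carry over to this one. No measurement shown here accounts for the size of the new step.

The change takes away an oxygen and a six-membered aromatic ring of carbon together, and the compounds shown cannot tell which of the two losses matters, or whether both do, since phenoxy and pentyl are the only groups compared at this place on a shared core. A cyclohexyloxy group would keep the oxygen without the aromatic ring and a benzyl group the aromatic ring without the oxygen, so either one at this position would begin to separate the two.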